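Three limits and a fourth compound awaiting its cytotoxicity reading

The compounds below may be only part of what the source reports. "The series", "measured", "known", "first", "only" and "open" are said of these compounds alone.

The study compares four close relatives of one core. Compound 1 is `C=CC1=C(C(=O)NCc2ccccc2F)C(c2ccc(F)cc2)OC1`, compound 2 is `C=CC1=C(C(=O)NCc2ccc(OC)c(OC)c2)C(c2ccc(F)cc2)OC1`, and compound 3 is `C=CC1=C(C(=O)NCc2ccccc2F)C(c2ccc(OC)cc2)OC1`. In a functional assay on A549 cells (Homo sapiens) for cytotoxicity, read by MTT assay, with a stated time of 24 h (a lower number here means a stronger inhibitor, a higher number a weaker inhibitor), compound 1 reaches only the limit of the assay, > 100000 nM. In this assay compound 2 likewise gives the limit > 100000 nM. Compound 3 also stops at the limit, > 100000 nM in this assay.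

The change from compound 1 to compound 3 is methoxy in place of fluoro on an aromatic carbon, and in this assay it made a step that the two limits leave unreadable from compound 1 to compound 3; the two values sit at the limit of > 100000 nM in this assay, at which 3 of the 3 values shown sit. The difference between the cores of compound 1 and compound 2 is not broken down here.

Compound 4, `C=CC1=C(C(=O)NCc2ccc(OC)c(OC)c2)C(c2ccc(OC)cc2)OC1`, has not yet been measured. It differs from compound 2 by methoxy in place of fluoro on an aromatic carbon, the same change as that from compound 1 to compound 3. Because all three values shown sit at the limit of > 100000 nM in this assay, at which 3 of the 3 values shown sit, the step that the limit leaves unreadable from compound 2 to compound 4 is expected to stay unreadable as well. Compound 4 is therefore estimated at 200000 nM in this assay, most likely reported again only as a limit.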

Compound 4, half-maximal inhibitory concentration: > 100000 nM
Compound 4 gave a limit, no number (the forecaster's own chance of this, stated with the estimate: 85%); the middle value is on the limit's open side.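

No new step can be read from compound 2 to compound 4, since neither compound gives a number, only a limit: the limit of > 100000 nM in this assay, at which 4 of the 4 values shown sit.

The compounds shown leave open whether any relative of this core reaches a readable value in this assay, and what size the change from 4-fluorophenyl to 4-methoxyphenyl would then have.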